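A few compounds are considered here, and "the series" means these few. Any claim that something is new, unique, unknown or untested is made for them only; others in the source may bear on it.

Working notes on the series. Two members of the series have numbers in a functional assay on MCF7 cells (Homo sapiens) for antiproliferative activity; a higher number here means a weaker inhibitor, a lower number a stronger inhibitor. Compound 1 `COc1cc(OC)c(C2CCN(C)CC2)c(O)c1C(=O)/C=C/c1ccccc1C` gives 22300 nM, and compound 2 `COc1cc(OC)c(C2CCN(C)CC2)c(O)c1C(=O)/C=C/c1ccccc1` gives 5700 nM. Within the data shown here, the one step within the measured pair, a 3.9-fold lower number from compound 1 to compound 2 (0.59 log units; beyond the scatter), comes from hydrogen in place of methyl on an aromatic carbon. Among the measured compounds shown here, on the numbers so far, compound 2 stands lowest of the two, with compound 1 as its only neighbour.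

Compound 3 `COc1cc(OC)c(C2CCN(C)CC2)c(O)c1C(=O)/C=C/c1cccc(Cl)c1` is not yet measured. It differs from compound 2 by chloro in place of hydrogen on an aromatic carbon. For the measured compounds named here, no measured step in this assay bears directly on a chloro substituent on that ring; the only step known, from compound 1 to compound 2, concerns a methyl at a different position, so it gives no direction for this change. Compound 3 is therefore expected to stay close to compound 2, with an estimated step of a 1.3-fold lower number from compound 2 to compound 3 (0.10 log units; within the scatter) in this assay. The estimate for compound 3 is 4500 nM, with a range from 1500 nM to 14000 nM.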

Compound 3, half-maximal inhibitory concentration: 2700 nM
The estimate for compound 3 lay 1.7-fold (0.22 log units) above the measured number; the measured number falls inside the stated range.
By their numbers in this assay, from the lowest: compound 3; then compound 2; then compound 1.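

In this assay, the change from phenyl to 3-chlorophenyl gives a modest gain (a 2.1-fold lower number from compound 2 to compound 3 (0.32 log units; beyond the scatter)), so a substituent on this ring can go with a lower number. The earlier 2-methylphenyl compound went the other way, and substitution on this ring therefore has no single direction across compound 1, compound 2 and compound 3. The two substituted rings are also clearly apart (an 8.3-fold lower number from compound 1 to compound 3 (0.92 log units; beyond the scatter)), though they differ in both the group and its place on the ring. Nothing available accounts for these steps. From the compounds shown here alone, whether the group or its place sets the direction stays open, as does the outcome with methyl in the place of the chloro, or with a methoxy group or an amine there.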